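Series notes: hydroxy to dimethylamino on the aryl ring

A few compounds are considered here, and "the series" means these few. Any claim that something is new, unique, unknown or untested is made for them only; others in the source may bear on it.

Measured in a functional assay on NCI/ADR cells (Homo sapiens) for cytotoxicity, read by sulforhodamine B assay; a higher number here means a weaker inhibitor of growth, a lower number a stronger inhibitor of growth:
compound 1 `CC1=CC[C@@H]([C@@](C)(O)CCCC(C)(C)NC(=S)N/N=C\c2ccccc2)CC1`: 6970 nM
compound 2 `COc1ccc(/C=N\NC(=S)NC(C)(C)CCC[C@](C)(O)[C@@H]2CC=C(C)CC2)cc1`: 6730 nM
compound 3 `CC1=CC[C@@H]([C@@](C)(O)CCCC(C)(C)NC(=S)N/N=C\c2ccc(O)cc2)CC1`: 8390 nM

Compound 3 lies within the scatter of both other compounds, as a 1.2-fold higher number from compound 1 to compound 3 (0.08 log units; within the scatter) and a 1.2-fold higher number from compound 2 to compound 3 (0.10 log units; within the scatter) show; the three numbers cannot be ordered. Compound 4 `CC1=CC[C@@H]([C@@](C)(O)CCCC(C)(C)NC(=S)N/N=C\c2ccc(N(C)C)cc2)CC1` differs from compound 3 by dimethylamino in place of hydroxy on an aromatic carbon. Among the compounds with values here, the steps that bear on this change all touch the same aromatic carbon: a 1.0-fold lower number from compound 1 to compound 2 (0.02 log units; within the scatter), a 1.2-fold higher number from compound 1 to compound 3 (0.08 log units; within the scatter) and a 1.2-fold higher number from compound 2 to compound 3 (0.10 log units; within the scatter), each within the scatter. Hydrogen, hydroxy and methoxy at this place left this assay unchanged, and nothing in the series speaks for a different outcome with dimethylamino. The expected step in this assay is therefore a 1.1-fold lower number from compound 3 to compound 4 (0.05 log units; within the scatter), none beyond the scatter. Compound 4 is estimated at 7500 nM, with a range of 3000 nM to 19000 nM.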

Compound 4, concentration for 50% growth inhibition: 25200 nM
Compound 4: middle estimate off by 3.4-fold (0.53 log units), on the low side; the whole stated range lies below it.
By their numbers in this assay, from the lowest: compounds 2, 1 and 3 (each within the scatter of the next); then compound 4.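

In this assay this place on the aromatic ring proves responsive: dimethylamino gives a 3.0-fold higher number from compound 3 to compound 4 (0.48 log units; beyond the scatter) and a 3.7-fold higher number from compound 2 to compound 4 (0.57 log units; beyond the scatter) and a 3.6-fold higher number from compound 1 to compound 4 (0.56 log units; beyond the scatter) as steps beyond the scatter, while hydrogen, hydroxy and methoxy cannot be told apart. All three steps point towards weaker growth inhibition, so the flat readings of compounds 1, 2 and 3 do not extend to every group here. No measurement shown accounts for the change. From the compounds shown here alone, whether an amino or diethylamino group at this carbon gives a step of similar size remains open.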